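A few compounds are considered here, and "the series" means these few. Any claim that something is new, unique, unknown or untested is made for them only; others in the source may bear on it.

Measured in a functional assay on A549 cells (Homo sapiens) for antiproliferative activity, read by MTT assay, with a stated time of 48 h; a higher number here means a weaker inhibitor of growth, a lower number a stronger inhibitor of growth:
- compound 1 `COC(=O)N1N=C(c2ccccc2)CC1c1cc(OC)c(OC)c(OC)c1`: 2880 nM
- compound 2 `COC(=O)N1N=C(c2cccc(OC)c2)CC1c1cc(OC)c(OC)c(OC)c1`: 2590 nM

Within the data shown here, compound 2, at 2590 nM, stands within the scatter of compound 1, the only other compound measured in this assay. Compound 3 `CCCOC(=O)N1N=C(c2cccc(OC)c2)CC1c1cc(OC)c(OC)c(OC)c1` keeps the rest of compound 2 and carries propoxycarbonyl in place of methoxycarbonyl, that is, ethyl in place of hydrogen on a saturated chain carbon bound to an oxygen next to a carbonyl group.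

Among the measured compounds shown here, no measured step touches this place. For the measured compounds named here, the single step available, a 1.1-fold lower number from compound 1 to compound 2 (0.05 log units; within the scatter), is methoxy in place of hydrogen on an aromatic carbon, so it gives neither a size nor a direction for this change. No step beyond the scatter is therefore expected, though the range stays wide. The expected step is a 1.1-fold higher number from compound 2 to compound 3 (0.03 log units; within the scatter). For compound 3 the estimated value is 2800 nM, with an expected range of 1100 nM to 7000 nM.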

Compound 3, concentration for 50% growth inhibition: > 10000 nM
Compound 3: only a limit was reported; the forecaster's own chance of this, stated with the estimate: 3%; at least 3.5-fold (0.55 log units) between middle value and limit.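

In this assay, among these compounds, this position proves sensitive to a change that adds only ethyl on a saturated chain carbon bound to an oxygen next to a carbonyl group: propoxycarbonyl in place of methoxycarbonyl gives an at least 3.8-fold higher number from compound 2 to compound 3 (0.58 log units; beyond the scatter), whereas the only earlier step, methoxy in place of hydrogen on an aromatic carbon, stayed within the scatter. Compound 3 gives > 10000 nM, which is a limit of the assay and not a number. The step therefore fixes a direction and a minimum size, but not a full size: the limit of > 10000 nM in this assay, at which 1 of the 3 values shown sits.

A single pair cannot show how growth inhibition depends on chain length at this position. Ethoxycarbonyl would test the shorter chain, while a carboxylic acid or an amide would show whether other groups at this place are tolerated.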